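The source may report more compounds than this note shows. Statements on the series, on what has been measured and on what is new or still open speak of the compounds shown alone.

Compound 1 `CC(Sc1nc2nn(C3(C)COC3)cc2c(=O)n1-c1ccccc1)c1ccccc1`: 50 nM
Compound 2 `CC(Sc1nc2c(cnn2C)c(=O)n1-c1ccccc1)c1cccc(F)c1`: 128 nM

In an assay on isolated protein for inhibition of Retinaldehyde dehydrogenase 3 (Homo sapiens) (a higher number here means a weaker inhibitor, a lower number a stronger inhibitor), compound 2 gives 128 nM, the higher of the two numbers, while compound 1 gives 50 nM, a lower number whose distance lies beyond the scatter. Compound 3 `CC(Sc1nc2c(cnn2C)c(=O)n1-c1ccccc1)c1cccc(O)c1` is not yet measured; it differs from compound 2 by hydroxy in place of fluoro on an aromatic carbon. Going by the values given here, no measured pair shows this change, so its size is unknown; a step within the scatter, in either direction, is expected. For compound 3 the expected value in this assay is 160 nM, with a range from 50 nM to 500 nM. The expected step is a 1.3-fold higher number from compound 2 to compound 3 (0.10 log units; within the scatter).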

Compound 3, half-maximal inhibitory concentration: 91 nM
Compound 3: middle estimate off by 1.8-fold (0.25 log units), on the high side, within the range that was stated.
By their numbers in this assay, from the lowest: compounds 1, 3 and 2 (each within the scatter of the next, the first and the last beyond it).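

At this position, meta to a large group, the change from 3-fluorophenyl to 3-hydroxyphenyl can now be read directly in this assay: a 1.4-fold lower number from compound 2 to compound 3 (0.15 log units; within the scatter). Hydroxy, which brings a hydrogen-bond donor, therefore stands in place of fluoro here without a difference beyond the scatter. No measurement shown accounts for this result. On these data alone, whether an amine, a methoxy group or a carboxylic acid at this place would also stay within the scatter remains open. So does whether the same change reads alike on the core of compound 1.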